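Swapping a benzyl-type group for propyl on the amide

This account rests on a few compounds, and the source may have more. Where it says the series, first, only, none or still open, it means among the compounds named here.

Measured so far:
compound 1, `Cc1ccc(CNC(=O)CN2C(=O)/C(=C/c3ccc(-c4ccc(Cl)cc4)o3)SC2=S)cc1`: 45000 nM
compound 2, `Cc1cccc(CNC(=O)CN2C(=O)/C(=C/c3ccc(-c4ccc(Cl)cc4)o3)SC2=S)c1`: 53000 nM

Compound 2 holds the higher of the two numbers in a functional assay on REH cells (Homo sapiens) for cytotoxicity, read by MTT assay, with a stated time of 72 h (a higher number here means a weaker inhibitor, a lower number a stronger inhibitor), but its step from compound 1, a 1.2-fold higher number from compound 1 to compound 2 (0.07 log units; within the scatter), falls within the scatter, so the two values are not told apart. Compound 3, `CCCNC(=O)CN1C(=O)/C(=C/c2ccc(-c3ccc(Cl)cc3)o2)SC1=S`, has not yet been measured in this assay. It differs from compound 2 in one place: ethyl in place of 3-methylphenyl on a saturated chain carbon bound to an amide-type nitrogen. For the measured compounds named here, the only measured step, from compound 1 to compound 2, moves a methyl group around an aromatic ring and says nothing about replacing that ring with a short chain. Going by the values given here, no measured pair therefore bears directly on this change. With both measured values sitting close together, the expectation for compound 3 rests on those values and the scatter alone, and the step of a 1.1-fold higher number from compound 2 to compound 3 (0.05 log units; within the scatter) is estimated as small, in no certain direction. Compound 3 is expected to give about 60000 nM in this assay, with a range from 20000 nM to 200000 nM.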

Compound 3, half-maximal inhibitory concentration: 55000 nM
Compound 3: the middle estimate sits 1.1-fold (0.04 log units) above what was measured, within the range that was stated.
By their numbers in this assay, from the lowest: compounds 1, 2 and 3 (each within the scatter of the next).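

In this assay, replacing the 3-methylbenzyl group on the amide nitrogen with propyl gives a readable step (a 1.0-fold higher number from compound 2 to compound 3 (0.02 log units; within the scatter)), and the comparison with the 4-methylphenyl analogue reads the same way (a 1.2-fold higher number from compound 1 to compound 3 (0.09 log units; within the scatter)). The earlier step only moved a methyl group around an aromatic ring, whereas these two steps remove that ring altogether, and the substituent on the saturated chain carbon bound to the amide-type nitrogen shrinks from 7 heavy atoms to 2 in the group exchanged, yet compounds 1, 2 and 3 still cannot be told apart. Among these three compounds, then, the aromatic ring at this position is not needed to keep the value in the same range, and nothing measured here offers an explanation for this.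

From the compounds shown here alone, all three substituents consist of carbon and hydrogen only and carry no net charge, so it remains open whether an amine or a carboxylic acid at this position would stand apart from them in this assay. A longer chain, such as octyl, and any change to the shared core also remain untested by the compounds shown here.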